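The source may report more compounds than this note shows. Statements on the series, on what has been measured and on what is new or still open speak of the compounds shown alone.

Working notes on the series. In a functional assay on GBM1 cells (Homo sapiens) for antiproliferative activity, read by WST assay, with a stated time of 72 h (on this read-out higher numbers stand for weaker inhibition and lower numbers for stronger inhibition), compound 1 (`O=C(Nc1ccc(Cl)c(Cl)c1)Nc1cc2ncncc2cc1OCc1ccccc1F`) gives 4100 nM and compound 2 (`O=C(Nc1cc2ncncc2cc1OCc1ccc(Cl)cc1)Nc1cccc2ccccc12`) gives 7900 nM on the same read-out. Among the measured compounds shown here, these are the only two numbers so far, and they lie within the scatter of each other, so compound 2 cannot be separated from compound 1. For the measured compounds named here, no measured pair differing in one place is available to size the next step.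

Compound 3 (`O=C(Nc1cc2ncncc2cc1OCc1ccc(F)cc1)Nc1cccc2ccccc12`) departs from compound 2 in one place. The change is fluoro in place of chloro on an aromatic carbon and reads as fluoro in place of chloro on an aromatic carbon, para to a large group, or 4-chlorobenzyl to 4-fluorobenzyl.

No shift beyond the scatter is expected in this assay for this swap. The estimated step of a 1.2-fold lower number from compound 2 to compound 3 (0.08 log units; within the scatter) is expected to stay within the scatter. For compound 3 the estimated value is 6500 nM with an expected range of 2500 nM to 15000 nM in this series.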

Compound 3, half-maximal inhibitory concentration: 8100 nM
Estimate against measurement, compound 3: 1.2-fold (0.10 log units) below; measured number inside the range.
By their numbers in this assay, from the lowest: compounds 1, 2 and 3 (each within the scatter of the next).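

In this assay, among the compounds shown here, fluoro in place of chloro on an aromatic carbon, para to a large group, gives a 1.0-fold higher number from compound 2 to compound 3 (0.01 log units; within the scatter) and is the first one-place step available. At this position, 4-chlorobenzyl and 4-fluorobenzyl therefore cannot be told apart on this read-out, so the exchange of these two halogens gives no measurable handle on antiproliferative activity here. No measurement at hand accounts for this result.

The compounds shown leave open whether an amine, a carboxylic acid or a methoxy group at the same place would give a step beyond the scatter. Compound 1 differs from compound 2 and compound 3 in more than one place, so the contribution of each of its differences cannot be read.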